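The compounds below may be only part of what the source reports. "The series", "measured", "known", "first", "only" and "open" are said of these compounds alone.

Three compounds of the series have been run so far in an ADME assay on RAW264.7 cells (Mus musculus) for cytotoxicity, read by neutral red uptake, with a stated time of 24 h; on this read-out lower numbers stand for higher toxicity in this test and higher numbers for lower toxicity in this test. Compound 1 `O=C(CN1C(=O)S/C(=C\c2ccc(C(F)(F)F)cc2)C1=O)NOCc1ccccc1` returns a value that is a limit of the assay, > 128000 nM. Compound 2 `C=CCONC(=O)CN1C(=O)S/C(=C\c2ccc(C(F)(F)F)cc2)C1=O` also returns a limit, > 128000 nM. Compound 3 `CC(C(=O)NOCc1ccccc1)N1C(=O)S/C(=C\c2ccc(F)cc2)C1=O` likewise gives only a limit, > 128000 nM. For the measured compounds named here, all three values reported so far fall at the limit of > 128000 nM in this assay, at which 3 of the 3 values shown sit, so none of the measured compounds can be placed above or below another on this read-out.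

The change from compound 1 to compound 2 is vinyl in place of phenyl on a saturated chain carbon bound to an oxygen. The corresponding step is a step that the two limits leave unreadable from compound 1 to compound 2; with both ends at the limit, its size cannot be read.

Compound 4 `C=CCONC(=O)C(C)N1C(=O)S/C(=C\c2ccc(F)cc2)C1=O` is the next to be measured in this assay. It stands to compound 3 as compound 2 stands to compound 1: the change is vinyl in place of phenyl on a saturated chain carbon bound to an oxygen, and the place is described in the same words, so it is the same change made on a second core. How the core of compound 3 differs from the core of compound 1 is not broken down here.

For compound 3 to compound 4 the expected step in this assay is a step that the limit leaves unreadable from compound 3 to compound 4, resting on the measured pair, where the same change left compound 1 at > 128000 nM and compound 2 at a limit as well. Compound 4 is estimated in this assay at 160000 nM, between 90000 nM and 400000 nM, and most likely to be reported once more as a limit.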

Compound 4, half-maximal cytotoxic concentration: > 128000 nM
Compound 4: no number, only a limit (the forecaster's own chance of this, stated with the estimate: 85%); the middle value lies beyond the limit too.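

In this assay no step can be read from compound 3 to compound 4, since both values are limits of the assay and not numbers: the limit of > 128000 nM in this assay, at which 4 of the 4 values shown sit.

The compounds shown leave open whether vinyl in place of phenyl on a saturated chain carbon bound to an oxygen shifts this read-out on either core, and how any of the four compounds ranks against the others.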